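The compounds below may be only part of what the source reports. "The series", "measured", "known", "first", "only" and "open" are said of these compounds alone.

Three compounds share one core and differ only at a single saturated ring carbon. Compound 1 `c1ccc(COc2cccc(-c3cn([C@@H]4CN5CCC4CC5)nn3)c2)cc1` is drawn with a defined configuration there; compound 2 `c1ccc(COc2cccc(-c3cn(C4CN5CCC4CC5)nn3)c2)cc1` is drawn without one; compound 3 `c1ccc(COc2cccc(-c3cn([C@H]4CN5CCC4CC5)nn3)c2)cc1` carries the opposite configuration. In an assay on HEK293 cells for displacement of a labelled ligand from Neuronal acetylcholine receptor; alpha4/beta2 (Homo sapiens), read by scintillation counting, with a stated time of 120 min (on this read-out higher numbers stand for weaker inhibition and lower numbers for stronger inhibition), compound 1 gives 414 nM, the smallest of the three numbers. Compound 2 gives 668 nM, and the step of a 1.6-fold higher number from compound 1 to compound 2 (0.21 log units; within the scatter) does not separate the two, which fits with the fact that one of compounds 1 and 2 is drawn with a defined configuration and the other without, at the place where they differ since an undrawn configuration can cover both forms. Compound 3 gives 5060 nM, so the step of a 12-fold higher number from compound 1 to compound 3 (1.09 log units; beyond the scatter) is clearly beyond the scatter, as is a 7.6-fold higher number from compound 2 to compound 3 (0.88 log units; beyond the scatter).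

Compound 4 `FCCCOc1cccc(-c2cn([C@@H]3CN4CCC3CC4)nn2)c1` keeps the configuration of compound 1 and changes a different place: 2-fluoroethyl in place of phenyl on a saturated chain carbon bound to an oxygen on an aromatic ring. Among the measured compounds shown here, none of the measured steps touches this part of the molecule, so they give no direct guide to its size or direction; they only show that the configuration kept in compound 4 is the one tied to the lower numbers. For the measured compounds named here, with no measured step bearing on the change, a value near that of compound 1 is expected, with wide uncertainty, which means an estimated step of a 1.4-fold higher number from compound 1 to compound 4 (0.16 log units; within the scatter). For compound 4 the estimate in this assay is 600 nM, with a range from 120 nM to 3000 nM.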

Compound 4, inhibition constant: 1980 nM
Estimate against measurement, compound 4: 3.3-fold (0.52 log units) below, and the stated range covers the measured number.
By their numbers in this assay, from the lowest: compounds 1 and 2 (each within the scatter of the next); then compound 4; then compound 3.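

Replacing the phenyl with 2-fluoroethyl, on a saturated chain carbon bound to an oxygen on an aromatic ring, gives a 4.8-fold higher number from compound 1 to compound 4 (0.68 log units; beyond the scatter) in this assay, so this place responds to what is attached there, something compounds 1, 2 and 3 could not show because they differ only in configuration at a saturated ring carbon. The step is modest, and compound 4 still gives a measurable number without the phenyl ring, so that ring is not required for displacement of the labelled ligand in this assay, even though removing it carries a cost. No measured fact shown here accounts for this step, and the swap removes a ring, shortens the group and adds a fluorine all at once.

Compound 4 alone cannot separate the loss of the ring from the arrival of the fluorine, and a plain propyl chain in place of 3-fluoropropyl would be the direct comparison for the fluorine. A benzyl ring carrying a fluorine, or a cyclohexylmethyl group in place of benzyl, would likewise test what the ring contributes.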